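Pyrrolidinyl dithiocarbamate replacing ethylpiperazinyl in the shared core

The source may hold more compounds than are shown below. What is called first, only, known or untested is meant among the compounds shown, and "the series" means these compounds.

Within the data shown here, compound 1 `CCN1CCN(C(=S)SCC(=O)N(Cc2ccc(OC)cc2)c2cc(OC)c(OC)c(OC)c2)CC1` gives 3070 nM in a functional assay on KYSE-450 cells (Homo sapiens) for inhibition, read by CCK-8 assay, with a stated time of 48 h (a higher number here means a weaker inhibitor, a lower number a stronger inhibitor), the highest of the two numbers measured so far; its nearest neighbour is compound 2 `COc1ccc(CN(C(=O)CSC(=S)N2CCN(C(=O)OC(C)(C)C)CC2)c2cc(OC)c(OC)c(OC)c2)cc1`, which in this assay gives 250 nM. Among the measured compounds shown here, the one measured step, a 12-fold lower number from compound 1 to compound 2 (1.09 log units; beyond the scatter), also alters the amine nitrogen of that ring and so bears on the change to compound 3 `COc1ccc(CN(C(=O)CSC(=S)N2CCCC2)c2cc(OC)c(OC)c(OC)c2)cc1`, where (pyrrolidin-1-yl in place of 4-ethylpiperazin-1-yl on a thiocarbonyl carbon). On that basis compound 3 is expected to show a 4.4-fold lower number from compound 1 to compound 3 (0.64 log units; beyond the scatter) in this assay, though the step is only partly comparable. The estimate for compound 3 is 700 nM, within 150 nM to 3000 nM.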

Compound 3, half-maximal inhibitory concentration: 13800 nM
Estimate against measurement, compound 3: 20-fold (1.29 log units) below; the whole stated range lies below it.
By their numbers in this assay, from the lowest: compound 2; then compound 1; then compound 3.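

In this assay, pyrrolidin-1-yl in place of 4-ethylpiperazin-1-yl on a thiocarbonyl carbon gives a 4.5-fold higher number from compound 1 to compound 3 (0.65 log units; beyond the scatter), the first move towards a higher number at this position. So this place on the shared core responds in both directions, and the one-hetero-atom five-membered ring falls on the weaker side of compound 1. No available evidence accounts for this change.

The compounds shown leave open whether ring size or the lost ring nitrogen carries the change. Piperidin-1-yl or morpholin-4-yl on the same thiocarbonyl carbon would help separate the two.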